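Compound 3 and a swapped group on the sulfonyl sulfur

The compounds below may be only part of what the source reports. "The series", "measured", "known", "first", "only" and "open" are said of these compounds alone.

Measured values in an ADME assay on HEK293 cells (Homo sapiens) for cytotoxicity, read by resazurin assay, with a stated time of 48 h (on this read-out higher numbers stand for lower toxicity in this test and lower numbers for higher toxicity in this test), are these
Compound 1 `CS(=O)(=O)Nc1ccc(-c2nc3ccccc3o2)cc1` gives > 100000 nM (a limit, not a number)
Compound 2 `CCc1ccc(S(=O)(=O)Nc2ccc(-c3nc4ccccc4o3)cc2)cc1` gives 82000 nM (a true number)

Among the compounds with values here, compound 2 gives 82000 nM as the only true number so far in this assay and so has no other number to be ranked against. Compound 1 stands at the limit of > 100000 nM in this assay, at which 1 of the 2 values shown sits, and has a limit rather than a number.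

Within the data shown here, compound 3 `COc1ccc(Cl)cc1S(=O)(=O)Nc1ccc(-c2nc3ccccc3o2)cc1` keeps the shared core and carries 5-chloro-2-methoxyphenyl in place of 4-ethylphenyl on a sulfonyl sulfur as its single change. Among the measured compounds shown here, the one measured step at this place is an at least 1.2-fold lower number from compound 1 to compound 2 (0.08 log units; that floor lies within the scatter) and it gives only a floor, so no step beyond the scatter is expected in this assay and no direction can be favoured. The expected step is a 1.1-fold lower number from compound 2 to compound 3 (0.04 log units; within the scatter) in this estimate. Compound 3 is estimated at 75000 nM with an expected range from 30000 nM to 100000 nM in this assay when it is measured.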

Compound 3, half-maximal cytotoxic concentration: 75000 nM
The estimate for compound 3 equals the measured number at the digits printed, within the range that was stated.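

In this assay, two quite different aryl groups on the sulfonyl sulfur cannot be told apart: 5-chloro-2-methoxyphenyl in place of 4-ethylphenyl gives a 1.1-fold lower number from compound 2 to compound 3 (0.04 log units; within the scatter). This swap brings in a chlorine, an oxygen and a hydrogen-bond acceptor, so compound 3 shows that this place tolerates these atoms with no step beyond the scatter, which a single true number could not show. Measured against the small methyl group, the same aryl group gives an at least 1.3-fold lower number from compound 1 to compound 3 (0.12 log units; that floor lies within the scatter), and this step is only a floor because compound 1 carries a limit rather than a number: the limit of > 100000 nM in this assay, at which 1 of the 3 values shown sits.

From the compounds shown here alone, both aryl groups compared here are six-membered carbon rings on the sulfonyl sulfur, so it stays open whether a group of another kind at this place, such as a basic amine, a carboxylic acid or a longer alkyl chain, would move the number in this assay beyond the scatter. Going by these compounds, the separate contributions of the chlorine and the methoxy group also stay open, since compound 3 carries both together.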